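Aryl variation at the imine carbon of the thiosemicarbazones

A few compounds are considered here, and "the series" means these few. Any claim that something is new, unique, unknown or untested is made for them only; others in the source may bear on it.

Compound 3 `CC1=CC[C@H](C(C)(C)NC(=S)N/N=C/c2ccccc2Cl)CC1` gives 5600 nM in a functional assay on K562 cells (Homo sapiens) for inhibition, read by sulforhodamine B assay, with a stated time of 48 h (on this read-out higher numbers stand for weaker inhibition of growth and lower numbers for stronger inhibition of growth), sitting with compound 1 `CC1=CC[C@H](C(C)(C)NC(=S)N/N=C/c2ccccc2)CC1` at 6300 nM among the two numbers shown, the pair separated only by a 1.1-fold lower number from compound 1 to compound 3 (0.05 log units; within the scatter) for chloro in place of hydrogen on an aromatic carbon. Compound 2 `CC1=CC[C@H](C(C)(C)NC(=S)N/N=C/c2ccc(O)cc2)CC1` reports only a limit in this assay, > 100000 nM. That limit is the limit of > 100000 nM in this assay, at which 1 of the 3 values shown sits. The aryl swap gives an at least 17-fold lower number from compound 2 to compound 3 (1.25 log units; beyond the scatter). Compound 4 `CC1=CC[C@H](C(C)(C)NC(=S)N/N=C/c2cccs2)CC1` differs from compound 3 by thiophen-2-yl in place of 2-chlorophenyl on a carbon with a double bond to nitrogen. Within the data shown here, the one aryl-for-aryl step that bears on it involved a hydroxy and was large, whereas the chloro step was within the scatter, so for compound 4 the expected step is a 1.2-fold higher number from compound 3 to compound 4 (0.06 log units; within the scatter), none beyond the scatter. Compound 4 is estimated at 6500 nM, with a range from 2000 nM to 25000 nM.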

Compound 4, concentration for 50% growth inhibition: 17600 nM
The estimate for compound 4 lay 2.7-fold (0.43 log units) below the measured number, within the range that was stated.
By their numbers in this assay, from the lowest: compounds 3 and 1 (each within the scatter of the next); then compound 4. At a limit, above all of these: compound 2.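

In this assay, replacing a six-membered aryl group at this carbon with thiophen-2-yl moves the number beyond the scatter, both against 2-chlorophenyl (a 3.1-fold higher number from compound 3 to compound 4 (0.50 log units; beyond the scatter)) and against phenyl (a 2.8-fold higher number from compound 1 to compound 4 (0.45 log units; beyond the scatter)), whereas the chloro step on the phenyl ring did not. Thiophen-2-yl still reads lower than 4-hydroxyphenyl (an at least 5.6-fold lower number from compound 2 to compound 4 (0.75 log units; beyond the scatter)). That step is bounded only, as compound 2 gives a limit: the limit of > 100000 nM in this assay, at which 1 of the 4 values shown sits.

As far as these compounds go, whether the ring size or the ring sulfur drives the thiophen-2-yl step remains open. Also open, from the compounds shown here alone, is how an amine or a carboxylic acid on the aryl ring would read.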